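Bromo in Place of Methyl, Carried to a Second Core

This account rests on a few compounds, and the source may have more. Where it says the series, first, only, none or still open, it means among the compounds named here.

Compound 1 `Cc1ccc(-c2cc3c(=N)sc(=S)[nH]c3n2-c2ccccc2)cc1`: 0%
Compound 2 `N=c1sc(=S)[nH]c2c1cc(-c1ccc(Br)cc1)n2-c1ccccc1`: 44%
Compound 3 `CCSc1nc2c(cc(-c3ccc(C)cc3)n2-c2ccccc2)c(=N)s1`: 0%

Of the compounds shown here, three have been tested in a functional assay on the whole organism for inhibition, with Rattus norvegicus as the target, read by ELISA, with stated times of 30 min and 6 h, at a dose of 30 mg/kg by the oral route; on this read-out lower numbers stand for less inhibition and higher numbers for more inhibition at the one dose given (going by the name of the read-out). Compound 1 gives 0% in this assay, and compound 2 gives 44%. The two differ by one change, (bromo in place of methyl on an aromatic carbon), and that change made a number 44 percentage points higher from compound 1 to compound 2 (beyond the scatter). Compound 3 shares the 4-methylphenyl group with compound 1 but carries a different core; the difference between the two cores is not broken down here. In this assay compound 3 gives 0%, level with compound 1 at the digits printed, and together the two stand as the lowest of the three numbers.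

Compound 4 `CCSc1nc2c(cc(-c3ccc(Br)cc3)n2-c2ccccc2)c(=N)s1` has not yet been measured. It differs from compound 3 by bromo in place of methyl on an aromatic carbon, the same change that led from compound 1 to compound 2, made at the same kind of place on the ring. Whether this step on the core of compound 3 repeats the size seen on the core of compound 1 is not known from a single earlier case. Within the data shown here, the expectation is an increase of a number 35 percentage points higher from compound 3 to compound 4 (beyond the scatter), resting on the step of a number 44 percentage points higher from compound 1 to compound 2 (beyond the scatter) as the only precedent, with wide bounds to cover the change of core. Compound 4 is therefore estimated at 35%, between 5% and 60%.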

Compound 4, a percentage reported as inhibition, in the whole organism at one dose (the size of the read-out at that dose, not a potency): 1%
Compound 4: the middle estimate sits 34 percentage points above what was measured; measured number outside the range, below it.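

Carried to the second core in this assay, bromo in place of methyl gave a number 1 percentage points higher from compound 3 to compound 4 (within the scatter), and compound 4 stands at 1%. Set beside the earlier case, the same change did not keep its size from one core to the other: the same change on two cores in this assay, a number 44 percentage points higher (beyond the scatter) from compound 1 to compound 2 and a number 1 percentage points higher (within the scatter) from compound 3 to compound 4, 43 percentage points apart, beyond the scatter of two such steps This shows that, in these four compounds, the gain seen on going to the 4-bromophenyl group on the core of compound 1 does not appear on the core of compound 3, but it does not show which feature of the two cores makes the difference, and it rests on a single pair for each core at one dose, so it cannot be taken as a rule for the series.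

The compounds shown leave open whether another group at the same place on the ring, such as chloro or methoxy, would follow the pattern of bromo on either core. They also leave open whether an amine or a longer chain on the core of compound 3, in place of the ethyl chain it carries, would allow the step seen on the core of compound 1 to return.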